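A few compounds are considered here, and "the series" means these few. Any claim that something is new, unique, unknown or untested is made for them only; others in the source may bear on it.

Two analogues with a shared core have been run in a functional assay on NCI-H226 cells (Homo sapiens) for inhibition, read by MTT assay, with a stated time of 48 h, tested at 10 uM; on this read-out higher numbers stand for more inhibition at the one concentration tested (going by the name of the read-out) and lower numbers for less inhibition: compound 1 `COc1cc(NC(=O)Nc2cc(Nc3ccc(C(C)(C)C)cc3)ncn2)cc(OC)c1` gives 47.7%, and compound 2 `CCc1ccc(Nc2cc(NC(=O)Nc3cc(OC)cc(OC)c3)ncn2)cc1` gives 50.1%. Compound 2 sits within the scatter of compound 1, the step of a number 2.4 percentage points higher from compound 1 to compound 2 (within the scatter) being small. Compound 3 `COc1cc(NC(=O)Nc2cc(Nc3ccc(C)c(C)c3)ncn2)cc(OC)c1` is not yet measured; it differs from compound 2 by 3,4-dimethylphenyl in place of 4-ethylphenyl on a nitrogen on an aromatic ring. Among the compounds with values here, the single measured step, ethyl in place of tert-butyl on an aromatic carbon, stayed within the scatter in this assay, so the present change is expected to do likewise, with a number 0.1 percentage points lower from compound 2 to compound 3 (within the scatter). Compound 3 is accordingly estimated at 50%, from 38% to 62%.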

Compound 3, a percentage reported as inhibition, at one concentration (the size of the read-out at that concentration, not a potency): 45.3%
Beside the measured number, compound 3's estimate is 4.7 percentage points above it; low and high end bracket the measured number.
By their numbers in this assay, from the lowest: compounds 3, 1 and 2 (each within the scatter of the next).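

At this position, 3,4-dimethylphenyl changes how the alkyl carbons are spread over the ring, not only the alkyl group itself, yet in this assay the result stays within the scatter (a number 4.8 percentage points lower from compound 2 to compound 3 (within the scatter)). The comparison with the 4-(tert-butyl)phenyl analogue reads the same way (a number 2.4 percentage points lower from compound 1 to compound 3 (within the scatter)). Nothing available bears on why these groups read alike.

All three groups on this nitrogen are alkyl-substituted phenyl rings. From the compounds shown here alone, whether an amine or a carboxylic acid on that ring would move the number beyond the scatter remains open.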